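This account rests on a few compounds, and the source may have more. Where it says the series, first, only, none or still open, it means among the compounds named here.

Compound 1 `COc1cc(OC)cc(C(=O)Nc2cc(-c3ccccc3)nn2-c2ccccc2)c1` in an assay on HEK293 cells for displacement of a labelled ligand from metabotropic glutamate receptor 5 (Rattus norvegicus) (a higher number here means a weaker inhibitor, a lower number a stronger inhibitor), reports only a limit, > 10000 nM. Compound 2 `Cc1ccc(C(=O)Nc2cc(-c3ccccc3)nn2-c2ccccc2)cc1C` gives 430 nM. Compound 3 `Cc1ccc(C(=O)Nc2cc(-c3ccccc3)nn2-c2ccccc2)cn1` gives 3480 nM.

Compound 3 stands highest of the two numbers shown, with compound 2 as its nearest neighbour by an 8.1-fold higher number from compound 2 to compound 3 (0.91 log units; beyond the scatter); the value of compound 1 is a limit, not a number. Compound 4 `O=C(Nc1cc(-c2ccccc2)nn1-c1ccccc1)C1CCCC1` differs from compound 3 by cyclopentyl in place of 6-methylpyridin-3-yl on a carbonyl carbon. Going by the values given here, no measured step exchanges an aromatic ring on the carbonyl carbon for a non-aromatic one; the steps of an at least 2.8-fold lower number from compound 1 to compound 3 (0.45 log units; beyond the scatter) and an 8.1-fold higher number from compound 2 to compound 3 (0.91 log units; beyond the scatter) show only that the group on that carbon shifts this assay by large amounts in both directions. A downward step of moderate size is expected, a 2.3-fold lower number from compound 3 to compound 4 (0.37 log units; beyond the scatter). Compound 4 is estimated at 1500 nM, within 300 nM to 8000 nM.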

Compound 4, inhibition constant: 11600 nM
The estimate for compound 4 lay 7.7-fold (0.89 log units) below the measured number; the whole stated range lies below it.
By their numbers in this assay, from the lowest: compound 2; then compound 3; then compound 4.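

Cyclopentyl is the first non-aromatic ring shown on this carbonyl carbon, and it gives a higher number in this assay than either aromatic group with a readable value, both steps lying beyond the scatter: the change from the 6-methylpyridin-3-yl group is modest (a 3.3-fold higher number from compound 3 to compound 4 (0.52 log units; beyond the scatter)) and the change from the 3,4-dimethylphenyl group is large (a 27-fold higher number from compound 2 to compound 4 (1.43 log units; beyond the scatter)). The aromatic rings thus differ among themselves, yet neither of these two is matched by cyclopentyl. Compound 1 reports only a limit, and its step to compound 4 cannot be read: the limit of > 10000 nM in this assay, at which 1 of the 4 values shown sits.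

Open, on these data alone, is whether an open carbon chain, or a cyclopentyl ring carrying an amine or a carboxylic acid, would read like cyclopentyl or like the aromatic groups.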